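A few compounds are considered here, and "the series" means these few. Any claim that something is new, unique, unknown or untested is made for them only; others in the source may bear on it.

Measured compounds:
- compound 1 `O=c1ccc2cc(OCc3cc(-c4ccccc4)no3)ccc2o1` — 53200 nM
- compound 2 `COc1cccc(-c2cc(COc3ccc4oc(=O)ccc4c3)on2)c1` — "not determined" (no result reported)
- compound 3 `O=c1ccc2cc(OCc3cc(-c4ccc(Cl)cc4)no3)ccc2o1` — "not determined" (no result reported)

In a functional assay on PC-3 cells (Homo sapiens) for cytotoxicity, read by MTT assay, with a stated time of 48 h (on this read-out lower numbers stand for stronger inhibition and higher numbers for weaker inhibition), compound 1 gives 53200 nM. For the measured compounds named here, compound 2 carries no result there, recorded as "not determined" (no result reported), and compound 3 likewise stands without a number, recorded as "not determined" (no result reported); no measured step connects it to any other compound, so the only anchor for the shared core is the single value of compound 1. Compound 4 `O=c1ccc2cc(OCc3cc(-c4ccccc4[N+](=O)[O-])no3)ccc2o1` differs from compound 3 by 2-nitrophenyl in place of 4-chlorophenyl on an aromatic carbon. Going by the values given here, with no comparable step recorded, no direction beyond the scatter can be expected in this assay. Compound 4 is estimated to give 45000 nM, within a range from 12000 nM to 160000 nM.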

Compound 4, half-maximal inhibitory concentration: 8200 nM
Beside the measured number, compound 4's estimate is 5.5-fold (0.74 log units) above it; the whole stated range lies above it.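

In this assay, for the compounds shown here, the first readable change at this position, on the aromatic carbon of the five-membered aromatic ring, is nitro in place of hydrogen on the phenyl group, which gives a 6.5-fold lower number from compound 1 to compound 4 (0.81 log units; beyond the scatter). This shows that the number responds to a change on that phenyl group, though a single step sets no trend. No measurement shown offers an explanation for the shift. Compound 3 and compound 2 carry no number, and their comparisons cannot be read. On these data alone, whether 2-aminophenyl or 4-nitrophenyl in the same place would give a similar number remains open.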